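Replacing the 2-phenylethenyl arm on the carbonyl carbon

A few compounds are considered here, and "the series" means these few. Any claim that something is new, unique, unknown or untested is made for them only; others in the source may bear on it.

Of the compounds shown here, two have numbers so far. In an ADME assay on L6 cells (Rattus norvegicus) for cytotoxicity, read by resazurin assay, with a stated time of 70 h (on this read-out higher numbers stand for weaker inhibition and lower numbers for stronger inhibition), compound 1 `COc1cc(NC(C)CCCNC(=O)/C=C/c2ccccc2)c2ncccc2c1` gives 7.2 ug/mL, and compound 2 `COc1cc(NC(C)CCCNC(=O)Nc2cccc(F)c2)c2ncccc2c1` gives 9.18 ug/mL in this assay. Within the data shown here, compound 1 holds the lowest of the two numbers, its only neighbour being a 1.3-fold higher number from compound 1 to compound 2 (0.11 log units; within the scatter), so nothing yet separates the two beyond scatter.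

Compound 3 `COc1cc(NC(C)CCCNC(=O)Nc2ccc(F)cc2)c2ncccc2c1` is still without a number. Against compound 1 the change is (4-fluorophenyl)amino in place of 2-phenylethenyl on a carbonyl carbon. Among the measured compounds shown here, the one measured step that bears on it is the entry of a (3-fluorophenyl)amino group at the same carbonyl carbon, which gave a 1.3-fold higher number from compound 1 to compound 2 (0.11 log units; within the scatter). For the measured compounds named here, with only that within-scatter step as a guide, no move beyond the scatter is expected in this assay. Compound 3 is therefore estimated at 8.5 ug/mL, with a range from 4 ug/mL to 18 ug/mL, which means an expected step of a 1.2-fold higher number from compound 1 to compound 3 (0.07 log units; within the scatter).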

Compound 3, half-maximal inhibitory concentration: 9.3 ug/mL
The estimate for compound 3 lay 1.1-fold (0.04 log units) below the measured number; low and high end bracket the measured number.
By their numbers in this assay, from the lowest: compounds 1, 2 and 3 (each within the scatter of the next).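

In this assay, (4-fluorophenyl)amino on the carbonyl carbon gives a 1.3-fold higher number from compound 1 to compound 3 (0.11 log units; within the scatter), so a second fluorinated arm at this position stays within the scatter of the 2-phenylethenyl arm. Exchanging 3-fluorophenyl for 4-fluorophenyl on the amide-type nitrogen gives a 1.0-fold higher number from compound 2 to compound 3 (0.01 log units; within the scatter), so this read-out does not separate these two fluorophenyl groups. Nothing at hand accounts for this flat result.

Across these three compounds, each arm entering the carbonyl carbon has an aromatic carbon ring, so it remains open whether the flat result holds for a dimethylamino group or a longer alkyl chain at this position. As far as these compounds go, it is also open whether a carboxylic acid or an amine on the phenyl ring would leave the number within the scatter.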